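The source may report more compounds than this note shows. Statements on the series, on what has been measured and on what is new or still open speak of the compounds shown alone.

Compound 1 `CCCCOC(=O)Nc1ccc([Se]C#N)cc1` was tested in a functional assay on HTB-54 cells (Homo sapiens) for cytotoxicity, read by MTT assay, with a stated time of 72 h (a higher number here means a weaker inhibitor of growth, a lower number a stronger inhibitor of growth), where compound 1 gives 43400 nM. Two related compounds, in which the carbamate-bearing aromatic part appears twice, joined through two selenium atoms, were measured in the same way. Compound 2 `CCOC(=O)Nc1ccc([Se][Se]c2ccc(NC(=O)OCC)cc2)cc1` gives 56600 nM in this assay, and compound 3 `CCCCCCOC(=O)Nc1ccc([Se][Se]c2ccc(NC(=O)OCCCCCC)cc2)cc1` gives 54300 nM. Compound 1 has the lowest of the three numbers, but its gaps to compound 2 and to compound 3 both lie within the usual scatter of repeated measurements, so the three cannot be told apart here.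

Compound 4 `C=CCOC(=O)Nc1ccc([Se]C#N)cc1` has not yet been measured. It differs from compound 1 in one place: vinyl in place of propyl on a saturated chain carbon bound to an oxygen next to a carbonyl group. For the measured compounds named here, no pair of measured compounds differs by a step of this kind, so its size cannot be read from the data. Since compound 1 at 43400 nM, compound 2 at 56600 nM and compound 3 at 54300 nM sit within the scatter of one another despite differing in their carbamate chains and selenium groups, compound 4 is expected to give about 40000 nM in this assay, within a range of 15000 nM to 100000 nM. The expected step from compound 1 to compound 4 is a 1.1-fold lower number from compound 1 to compound 4 (0.04 log units; within the scatter), meaning no change beyond the scatter.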

Compound 4, concentration for total growth inhibition: 50100 nM
Beside the measured number, compound 4's estimate is 1.3-fold (0.10 log units) below it; the measured number falls inside the stated range.
By their numbers in this assay, from the lowest: compounds 1, 4, 3 and 2 (each within the scatter of the next).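

For the compounds shown here, this is the first change in the set made at a single place, and it gives a direct reading of the carbamate chain: in this assay, vinyl in place of propyl on a saturated chain carbon bound to an oxygen next to a carbonyl group gives a 1.2-fold higher number from compound 1 to compound 4 (0.06 log units; within the scatter). At this position, then, the butyl chain of compound 1 and the allyl chain of compound 4, with its double bond and its shorter length, cannot be told apart in this assay. Nothing measured on these compounds bears on why the two chains read alike.

Still open, from the compounds shown here alone, is whether a different kind of group here, such as an amine, a carboxylic acid or a much longer chain, would move the number beyond the scatter. Also open, going by these compounds, is what the nitrile on selenium, shared by compound 1 and compound 4, contributes to the number.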